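Chloro in place of phenyl on compound 1

The source may report more compounds than this note shows. Statements on the series, on what has been measured and on what is new or still open speak of the compounds shown alone.

Compound 1 (`O=C(Nc1cccc(-c2ccc(-c3ccccc3)cc2)c1)C(Cl)Cl`) is the starting point in a functional assay on KB 3-1 cells (Homo sapiens) for cytotoxicity, read by MTT assay, with a stated time of 68 h; a lower number here means a stronger inhibitor, a higher number a weaker inhibitor. Compound 1 reads > 50000 nM, which is a limit and not a number. Two relatives give actual numbers: compound 2 (`O=C(Nc1cccc(-c2ccccc2F)c1)C(Cl)Cl`) gives 48300 nM and compound 3 (`O=C(Nc1cc(-c2ccc(OC3CCCCO3)cc2)cc(-c2ccc(OC3CCCCO3)cc2)c1)C(Cl)Cl`) gives 7220 nM.

Compound 4 (`O=C(Nc1cccc(-c2ccc(Cl)cc2)c1)C(Cl)Cl`) is compound 1 with chloro in place of phenyl on an aromatic carbon, para to a large group: chloro in place of phenyl on an aromatic carbon.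

Within the data shown here, no measured pair differs in one place only, so the size of this step has no direct precedent. The closest guide is compound 2, which also carries a single halogen and gives 48300 nM. On that basis, a modest move toward a stronger reading is expected in this assay, and a result that again stops at a limit remains possible. The expected change is an at least 1.7-fold lower number from compound 1 to compound 4 (0.25 log units; that floor lies within the scatter), an estimate that starts from a limit. For compound 4 the estimated value is 28000 nM, with an expected range of 10000 nM to 50000 nM.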

Compound 4, half-maximal inhibitory concentration: 38200 nM
Compound 4: middle estimate off by 1.4-fold (0.13 log units), on the low side, and the stated range covers the measured number.
By their numbers in this assay, from the lowest: compound 3; then compounds 4 and 2 (each within the scatter of the next). At a limit, above all of these: compound 1.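

In this assay, among these compounds, chloro in place of phenyl on this aromatic carbon, para to a large group, gives an at least 1.3-fold lower number from compound 1 to compound 4 (0.11 log units; that floor lies within the scatter), the first step between compounds that differ in one place. Compound 4 gives 38200 nM, an actual number, so this change yields a reading that can be placed in the series. Compound 1 reads > 50000 nM, which is a limit and not a number, and the true size of the step stays unknown because of it: the limit of > 50000 nM in this assay, at which 1 of the 4 values shown sits.

Open, on these data alone, is how other groups behave on the same carbon: a methoxy, an amine or a carboxylic acid in place of chloro would each give a step of the same kind. Compound 2 and compound 3 differ from compound 4 in more than one place, so nothing shown links them to it by a single change.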